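A few compounds are considered here, and "the series" means these few. Any claim that something is new, unique, unknown or untested is made for them only; others in the source may bear on it.

Of the compounds shown here, three have been measured in a functional assay on HTB-54 cells (Homo sapiens) for cytotoxicity, read by MTT assay, with a stated time of 72 h; on this read-out higher numbers stand for weaker inhibition of growth and lower numbers for stronger inhibition of growth. Compound 1 `COc1ccc(OC(=O)Nc2ccc([Se]C#N)cc2)cc1` gives 23700 nM, compound 2 `O=C(Nc1ccc([Se][Se]c2ccc(NC(=O)OCc3ccccc3)cc2)cc1)OCc1ccccc1` gives 23800 nM, and compound 3 `CCCCOC(=O)Nc1ccc([Se]C#N)cc1` gives 17200 nM. Compound 3 has the lowest of the three numbers, but its gaps to compound 1 and to compound 2 both lie within the usual scatter of repeated measurements, so no order among the three can be claimed. Compound 4 `C=CCOC(=O)Nc1ccc([Se]C#N)cc1` has not yet been measured. It differs from compound 3 by vinyl in place of propyl on a saturated chain carbon bound to an oxygen next to a carbonyl group. Within the data shown here, no measured pair shows a comparable change, so the step is expected to stay within the scatter, with no clear direction. In this assay compound 4 is therefore expected to give about 17000 nM, somewhere between 8000 nM and 36000 nM. The expected step of a 1.0-fold lower number from compound 3 to compound 4 (0.01 log units; within the scatter) is accordingly small.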

Compound 4, concentration for 50% growth inhibition: 27000 nM
For compound 4 the middle estimate is 1.6-fold (0.20 log units) below the measured one, within the range that was stated.
By their numbers in this assay, from the lowest: compounds 3, 1, 2 and 4 (each within the scatter of the next).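

In this assay, among these compounds, the step of a 1.6-fold higher number from compound 3 to compound 4 (0.20 log units; within the scatter) is the only measured change on this saturated chain carbon bound to an oxygen next to a carbonyl group. It shows that, in this one pair, vinyl in place of propyl, which makes the butyl chain an allyl chain, leaves the number within the scatter. No measurement at hand offers an explanation for this result.

One pair cannot show how other groups would behave here. A longer chain such as octyl, or a chain ending in an amine or a carboxylic acid, remains an open case.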